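The source may report more compounds than this note shows. Statements on the series, on what has been measured and on what is new or still open speak of the compounds shown alone.

Measured compounds in a functional assay on a cell-free system (Platelet, plasma, Homo sapiens), with stated times of 4 min and 5.5 min, tested at 1 uM; on this read-out higher numbers stand for a weaker effect at the one concentration tested and lower numbers for a stronger effect:

Compound 1, `O=C(C1CCCN(Cc2ccccc2)C1)N1CCN(c2ccccc2Cl)CC1`: 22%
Compound 2, `O=C(C1CCCN(Cc2ccc(Br)cc2)C1)N1CCN(c2ccccc2Cl)CC1`: 39%

Compound 2 holds the highest of the two numbers, and its nearest neighbour is compound 1. Within the data shown here, the one measured step, a number 17 percentage points higher from compound 1 to compound 2 (beyond the scatter), came with bromo in place of hydrogen on an aromatic carbon, so the bromo compound showed the weaker effect at the single concentration tested.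

Compound 3, `O=C(C1CCCN(Cc2ccc([N+](=O)[O-])cc2)C1)N1CCN(c2ccccc2Cl)CC1`, is still to be measured. It differs from compound 2 in one place: nitro in place of bromo on an aromatic carbon.

Among the measured compounds shown here, no measured step swaps one group for another at this position; the step from compound 1 to compound 2 only shows that putting a group there, rather than hydrogen, moved the number modestly upward. On these data alone, whether nitro behaves like bromo is unknown from these two compounds alone, so the best guess is that compound 3 stays near compound 2, with a wide margin either way. Compound 3 is therefore expected to give 38% in this assay, within a range from 18% to 60%. This estimate means a step of a number 1 percentage points lower from compound 2 to compound 3 (within the scatter), expected to stay within the scatter.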

Compound 3, a percentage reported as activity, at one concentration (the size of the read-out at that concentration, not a potency): 23%
For compound 3 the middle estimate is 15 percentage points above the measured one; the range from low to high includes it.
By their numbers in this assay, from the lowest: compounds 1 and 3 (each within the scatter of the next); then compound 2.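

In this assay, the change from 4-bromobenzyl to 4-nitrobenzyl gave a number 16 percentage points lower from compound 2 to compound 3 (beyond the scatter) and so shows that this position does not treat every group alike: the identity of the group on the aromatic carbon matters, not merely the fact that something has replaced hydrogen. Placing nitro rather than hydrogen at the same carbon gave a number 1 percentage points higher from compound 1 to compound 3 (within the scatter) and so leaves compound 3 level with compound 1, which means that among the three compounds only the bromo compound, compound 2, stands apart, with the weaker effect at the one concentration tested. Nothing available explains why bromo and nitro differ here.

The compounds shown leave open whether an amine or a carboxylic acid on this carbon would fall with compound 1 and compound 3 or with compound 2. They also leave open whether chloro or fluoro would follow bromo, and whether nitro and bromo would differ in the same way on a different carbon of the aromatic ring.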